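A few compounds are considered here, and "the series" means these few. Any claim that something is new, unique, unknown or untested is made for them only; others in the source may bear on it.

Compound 2, with the structure `Nc1nc([SeH])nc2ncccc12`, gives 44300 nM in a functional assay on HTB-54 cells (Homo sapiens) for cytotoxicity, read by MTT assay, with a stated time of 72 h; on this read-out lower numbers stand for stronger inhibition of growth and higher numbers for weaker inhibition of growth. Among the two numbers shown it is the higher one; its nearest neighbour, compound 1, with the structure `C[Se]c1nc(N)c2ccccc2n1`, gives 18000 nM, a lower number, and the gap between the two lies beyond the usual scatter. Compound 3, with the structure `[SeH]c1nc(NCc2ccccc2)c2cccnc2n1`, sits at the limit of > 100000 nM in this assay, at which 1 of the 3 values shown sits, so for compound 3 this assay gives only a limit, > 100000 nM.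

The step considered here leads from compound 2 to compound 4, with the structure `[SeH]c1nc([SeH])c2cccnc2n1`. The change is one selenium atom in place of one nitrogen atom, on an aromatic carbon. Among the compounds with values here, no measured pair shows this change, so its size can only be guessed. Compound 4 is expected to give 70000 nM in this assay, somewhere between 25000 nM and 200000 nM. This estimate means a step from compound 2 to compound 4 of a 1.6-fold higher number from compound 2 to compound 4 (0.20 log units; within the scatter), a modest move toward weaker inhibition that may not exceed the scatter, with a real chance that only a limit is reported.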

Compound 4, concentration for 50% growth inhibition: 4030 nM
For compound 4 the middle estimate is 17-fold (1.24 log units) above the measured one; the whole stated range lies above it.
By their numbers in this assay, from the lowest: compound 4; then compound 1; then compound 2. At a limit, above all of these: compound 3.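

Placed on an aromatic carbon of a six-membered aromatic ring with 2 nitrogen, opposite the ring nitrogen, a selenium atom in place of the amino group gives an 11-fold lower number from compound 2 to compound 4 (1.04 log units; beyond the scatter) in this assay, a large move toward stronger inhibition of growth. Within the data shown here, every earlier compound holds a nitrogen atom at this place, so this step is the first to show that the read-out responds strongly to the atom attached there. The data shown offer no explanation for the size of this step.

A single step cannot separate what the entering selenium contributes from what the leaving amino group contributes, and a thiol or a hydroxyl group at the same place would speak to that. Going by these compounds, whether the same change carries over to the core of compound 1 also stays open.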